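The compounds below may be only part of what the source reports. "The series", "measured", "known", "first", "only" and "open" are said of these compounds alone.

Within the data shown here, compound 2, with the structure `COc1cc(NC(C)CCCNC(=O)NNC(=O)/C=C/c2ccccc2F)c2ncccc2c1`, is the only member of this small set for which a number has been reported in an ADME assay on L6 cells (Rattus norvegicus) for cytotoxicity, read by resazurin assay, with a stated time of 70 h; on this read-out lower numbers stand for stronger inhibition and higher numbers for weaker inhibition: compound 2 gives 25100 nM. Compound 1, with the structure `COc1cc(NC(C)CCCNC(=O)NCc2ccncc2)c2ncccc2c1`, shares the same core but carries no result in this assay, where compound 1 is given as "not determined" (no result reported), so no comparison between compound 1 and compound 2 can be drawn. Compound 3, with the structure `COc1cc(NC(C)CCCNC(=O)NNC(=O)Nc2ccc(Cl)cc2)c2ncccc2c1`, has not yet been measured in this assay.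

Compound 3 differs from compound 2 in a single place: (4-chlorophenyl)amino in place of 2-(2-fluorophenyl)ethenyl on a carbonyl carbon. The replaced group and the entering group are of similar size, each with one six-membered aromatic ring of carbon only, while the entering group brings one hydrogen-bond donor and loses the double bond outside aromatic rings.

Among the measured compounds shown here, with no measured step available to anchor the size of this change, the expectation for compound 3 is that it stays close to compound 2, with a step of a 1.2-fold higher number from compound 2 to compound 3 (0.08 log units; within the scatter) that is not expected to go beyond the usual scatter in either direction. Compound 3 is therefore estimated at 30000 nM, within a range from 10000 nM to 90000 nM.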

Compound 3, half-maximal inhibitory concentration: 91900 nM
Compound 3: the middle estimate sits 3.1-fold (0.49 log units) below what was measured, and the stated range ends below it.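

In this assay, the group on this carbonyl carbon proves not to be interchangeable, a point that a single number could not establish: a 3.7-fold higher number from compound 2 to compound 3 (0.56 log units; beyond the scatter), a modest move toward weaker inhibition that lies beyond the scatter. The replaced and entering groups each hold one six-membered aromatic ring of carbon only, so a shift in the read-out can arise at this position even when that ring count stays the same. The change nevertheless bundles several differences, with a double bond outside aromatic rings leaving, a hydrogen-bond donor entering and chlorine taking the place of fluorine, and nothing available here ties the step to any one of them.

The compounds shown leave open whether the step follows the amino link or the halogen on the ring, a question that (2-fluorophenyl)amino or unsubstituted phenylamino on the same carbonyl carbon would help to separate. They also leave open how far the read-out extends at this position with a group lacking an aromatic ring, such as a simple ethylamino group.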